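Aryl swap on the saturated ring carbon: compound 2 to compound 4

The source may report more compounds than this note shows. Statements on the series, on what has been measured and on what is new or still open speak of the compounds shown alone.

Three compounds of this series have numbers in a functional assay on MDA-MB-231 cells (Homo sapiens) for antiproliferative activity, read by MTT assay, with a stated time of 48 h; a lower number here means a stronger inhibitor, a higher number a weaker inhibitor. Compound 1 `COc1ccc(OC)c([C@@H]2[C@H](OC)C(=O)N2C/C(C#N)=C/c2ccccc2)c1` gives 23400 nM. Compound 2 `COC(=O)/C(=C/c1ccccc1)CN1C(=O)[C@@H](OC)[C@H]1c1cccc(F)c1` gives 34400 nM. Compound 3 `CCOC(=O)/C(=C/c1ccccc1)CN1C(=O)[C@@H](OC)[C@H]1c1ccccc1Br` gives 6860 nM. Compound 2 stands at the highest of the three numbers; compound 1 lies within the scatter of it, while compound 3 lies beyond the scatter with a lower number. Going by the values given here, compound 3 differs from compound 2 in more than one place, so no single-change step between measured compounds is available.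

Compound 4 `COC(=O)/C(=C/c1ccccc1)CN1C(=O)[C@@H](OC)[C@H]1c1ccc(Cl)cc1Cl` differs from compound 2 at one place only: 2,4-dichlorophenyl in place of 3-fluorophenyl on a saturated ring carbon. Nothing measured isolates this change, and compound 3 cannot serve as a guide to it, since several parts of its structure differ at once. A small step toward a lower number is expected from compound 2 to compound 4 in this assay, of a size that may not clear the scatter. Compound 4 is estimated at 16000 nM with a range of 5000 nM to 45000 nM. The expected step is a 2.2-fold lower number from compound 2 to compound 4 (0.33 log units; beyond the scatter).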

Compound 4, half-maximal inhibitory concentration: 19000 nM
Compound 4: middle estimate off by 1.2-fold (0.07 log units), on the low side; measured number inside the range.
By their numbers in this assay, from the lowest: compound 3; then compounds 4, 1 and 2 (each within the scatter of the next).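

In this assay, going by these compounds alone, the first single-change step reads a 1.8-fold lower number from compound 2 to compound 4 (0.26 log units; within the scatter); this lies within the scatter, so 2,4-dichlorophenyl and 3-fluorophenyl on this saturated ring carbon are not told apart. In this one pair, replacing the single fluorine with two chlorines on the phenyl ring moves the read-out by no more than the scatter. No measurement is available that would explain this result.

On these data alone, it stays open whether a phenyl ring bearing an amine or a carboxylic acid, or a cyclohexyl group in place of the aryl ring, would give a step beyond the scatter at this carbon. As far as these compounds go, it also stays open whether the same aryl swap would read alike with a nitrile in place of the methyl ester.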